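From pyridin-3-yl to 6-methylpyridin-2-yl: compound 2 to compound 4

The source may report more compounds than this note shows. Statements on the series, on what has been measured and on what is new or still open speak of the compounds shown alone.

Measured in a functional assay on NFS-60 cells (Mus musculus) for inhibition, with a stated time of 72 h; on this read-out higher numbers stand for weaker inhibition of growth and lower numbers for stronger inhibition of growth:
compound 1 `Nc1ncnc2c(C(=O)Nc3cccc4c3c(Br)nn4Cc3ccccn3)csc12`: 2500 nM
compound 2 `Nc1ncnc2c(C(=O)Nc3cccc4c3c(Br)nn4Cc3cccnc3)csc12`: 77 nM
compound 3 `Nc1ncnc2c(C(=O)Nc3cccc4c3c(Br)nn4Cc3cccc(Br)n3)csc12`: 243 nM

Compound 2 has the lowest number of the three, and its gaps to both others lie beyond the scatter. Compound 4 `Cc1cccc(Cn2nc(Br)c3c(NC(=O)c4csc5c(N)ncnc45)cccc32)n1` is the next to be read, and it differs from compound 2 as follows: 6-methylpyridin-2-yl in place of pyridin-3-yl on a saturated chain carbon bound to an aromatic nitrogen.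

For the measured compounds named here, three measured steps bear on this change. Moving to pyridin-3-yl from pyridin-2-yl gave a 32-fold lower number from compound 1 to compound 2 (1.51 log units; beyond the scatter), a large step. Bromo in place of hydrogen on an aromatic carbon gave a 10-fold lower number from compound 1 to compound 3 (1.01 log units; beyond the scatter), also large. The closest match is 6-bromopyridin-2-yl in place of pyridin-3-yl, which gave a 3.2-fold higher number from compound 2 to compound 3 (0.50 log units; beyond the scatter), a modest step. Going by the values given here, no measured compound here carries the methyl, so the bromo steps are only a guide. A modest rise in the number is therefore expected, with a large one possible. The expected step is a 4.5-fold higher number from compound 2 to compound 4 (0.66 log units; beyond the scatter). The estimate for compound 4 is 350 nM, with an expected range of 120 nM to 1000 nM.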

Compound 4, concentration for 50% growth inhibition: 27.5 nM
For compound 4 the middle estimate is 13-fold (1.10 log units) above the measured one, and the stated range ends above it.
By their numbers in this assay, from the lowest: compound 4; then compound 2; then compound 3; then compound 1.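

Methyl on the pyridin-2-yl ring gives a 91-fold lower number from compound 1 to compound 4 (1.96 log units; beyond the scatter) in this assay and turns the weakest ring of the set into the best one, since the 6-methylpyridin-2-yl group also gives a 2.8-fold lower number from compound 2 to compound 4 (0.45 log units; beyond the scatter) against pyridin-3-yl. The two substituted pyridin-2-yl rings do not read alike: methyl in place of bromo gives an 8.8-fold lower number from compound 3 to compound 4 (0.95 log units; beyond the scatter) and leaves compound 4 with the lowest number of the four, beyond the scatter against each of the others. The data offer no measured explanation for these steps.

From the compounds shown here alone, whether this gain is specific to methyl remains open, as ethyl, methoxy or an amine on the same ring could read differently. Going by these compounds, it is also open whether a methyl group on the pyridin-3-yl ring of compound 2 would add to that ring's number in the same way.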